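The source may hold more compounds than are shown below. What is called first, only, known or untested is meant among the compounds shown, and "the series" means these compounds.

Measured so far in a physicochemical assay for lipophilicity, read by LC-MS, measured as octanol-water partition, with a stated time of 2 h, at pH 7.4, tested at 1 uM; a higher number here means a more lipophilic compound, a lower number a more polar compound:
- compound 1 `OC[C@H]1O[C@H](Oc2ccc(-c3ccc(Cl)cc3Cl)cc2Cl)[C@@H](O)[C@@H](O)[C@@H]1O`: "not determined" (no result reported)
- compound 2 `N#Cc1cccc(-c2ccc(O[C@H]3O[C@H](CO)[C@@H](O)[C@H](O)[C@@H]3O)c(Cl)c2)c1`: 2.1
- compound 3 `N#Cc1ccc(-c2ccc(O[C@H]3O[C@H](CO)[C@@H](O)[C@H](O)[C@@H]3O)c(Cl)c2)cc1`: 2.1

Compound 2 stands at 2.1, level with compound 3, and compound 1 offers no number for comparison. Compound 4 `OC[C@H]1O[C@H](Oc2ccc(-c3cccc(C(F)(F)F)c3)cc2Cl)[C@@H](O)[C@@H](O)[C@@H]1O` has trifluoromethyl in place of cyano on an aromatic carbon. Going by the values given here, the only measured step, no change at the digits printed from compound 2 to compound 3 (within the scatter), is 4-cyanophenyl in place of 3-cyanophenyl, so it retains the nitrile and gives no size for exchanging it. The expectation of an upward move in this assay therefore rests on the structural change alone, and its size is uncertain. The expected change is a number 1.00 log units higher from compound 2 to compound 4 (beyond the scatter). For compound 4 the estimate is 3.1, with an expected range of 2.6 to 3.6.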

Compound 4, distribution coefficient: 3.3
Estimate against measurement, compound 4: 0.20 log units below; the range from low to high includes it.
By their numbers in this assay, from the lowest: compounds 2 and 3 (each within the scatter of the next); then compound 4.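

In this assay the exchange of cyano for trifluoromethyl on an aromatic carbon, meta to a large group, gives a number 1.20 log units higher from compound 2 to compound 4 (beyond the scatter) and so sizes a change of group at this position. Moving the nitrile had given no change at the digits printed from compound 2 to compound 3 (within the scatter) and said nothing about exchanging it. Nothing shown accounts for the size of this step.

Open, on these data alone, is whether an amine or a carboxylic acid on the same carbon would shift the number as far. Also open, as far as these compounds go, is whether trifluoromethyl at the place of the nitrile in compound 3 would match compound 4.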